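Chloro addition on the aromatic ring: clearance notes

The compounds below may be only part of what the source reports. "The series", "measured", "known", "first", "only" and "open" are said of these compounds alone.

Measured so far:
- compound 1 `Nc1nccc(COc2ccc3nc(N[C@@H]4CCCC[C@H]4O)sc3c2)c1Cl`: 68 mL/min/kg
- compound 2 `Nc1nccc(COc2cc(Cl)c3nc(N[C@@H]4CCCC[C@H]4O)sc3c2)c1Cl`: 78 mL/min/kg
- compound 3 `COc1cc(OCc2ccnc(N)n2)cc2sc(N[C@H]3CCCC[C@@H]3O)nc12`: 20 mL/min/kg

In an ADME assay on microsomes from liver (Rattus norvegicus, strain Sprague-Dawley) for pharmacokinetics, read by LC-MS, using NADPH, with a stated time of 45 min, tested at 1 uM (on this read-out higher numbers stand for fast clearance and lower numbers for slow clearance), compound 1 gives 68 mL/min/kg and compound 2 gives 78 mL/min/kg. The change between them, (chloro in place of hydrogen on an aromatic carbon), gave a 1.1-fold higher number from compound 1 to compound 2 (0.06 log units; within the scatter). Compound 3 gives 20 mL/min/kg, the lowest of the three; the difference between its core and that of compound 1 is not broken down here.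

Compound 4 `COc1cc(OCc2ccnc(N)n2)c(Cl)c2sc(N[C@H]3CCCC[C@@H]3O)nc12` is not yet measured. It differs from compound 3 by chloro in place of hydrogen on an aromatic carbon, the same kind of change as from compound 1 to compound 2, though the place differs: here it is ortho to a (2-aminopyrimidin-4-yl)methoxy group and para to a methoxy group, whereas there it was meta to a large group. Since the earlier step of a 1.1-fold higher number from compound 1 to compound 2 (0.06 log units; within the scatter) was within the scatter, the expected step is a 1.1-fold higher number from compound 3 to compound 4 (0.04 log units; within the scatter), also small. Compound 4 is estimated at 22 mL/min/kg, between 11 mL/min/kg and 45 mL/min/kg.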

Compound 4, clearance: 43 mL/min/kg
The estimate for compound 4 lay 2.0-fold (0.29 log units) below the measured number, within the range that was stated.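

In this assay the swap of hydrogen for chloro gives a 2.2-fold higher number from compound 3 to compound 4 (0.33 log units; beyond the scatter), a modest step but one that stands clear of the usual scatter on this core. The two steps cannot be told apart, so the data do not show that the core changes the outcome of this swap: the same change on two cores in this assay, a 1.1-fold higher number (0.06 log units; within the scatter) from compound 1 to compound 2 and a 2.2-fold higher number (0.33 log units; beyond the scatter) from compound 3 to compound 4, 1.9-fold (0.27 log units) apart, within the scatter of two such steps. Nor do they show that the swap carries over unchanged, as only two pairs are shown and the chloro sits in a different place on each, so the effects of core and place remain unseparated.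

From the compounds shown here alone, it remains open how chloro would behave at the same place on both cores. Going by these compounds, it also remains open whether a methyl group or an amine at that place would give a similar step.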